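The source may hold more compounds than are shown below. What is called first, only, known or untested is meant among the compounds shown, and "the series" means these compounds.

Working notes on the series. Compound 1 `C#CCNCc1cc2ccccc2n1C` carries a propargyl group on a secondary amine; in an assay on isolated protein for inhibition of Amine oxidase [flavin-containing] A (Rattus norvegicus) (on this read-out lower numbers stand for stronger inhibition and higher numbers for weaker inhibition), compound 1 gives 240 nM. Compound 2 `C#CCN(Cc1ccccc1)Cc1cc2ccccc2n1C` adds a benzyl group to that nitrogen; in this assay compound 2 gives 10000 nM. Among the measured compounds shown here, the single step measured so far, a 42-fold higher number from compound 1 to compound 2 (1.62 log units; beyond the scatter), shows that benzyl in place of hydrogen on the amine nitrogen weakens inhibition strongly. For the measured compounds named here, on the numbers at hand compound 2 stands highest of the two, with compound 1 as its only neighbour.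

Compound 3 `Cn1c(CNCc2ccccc2)cc2ccccc21` is the next step from compound 2: hydrogen in place of propargyl on an amine nitrogen. Going by the values given here, no measured step removes the propargyl group, so the step from compound 2 to compound 3 has no direct precedent. What is known is that compound 1, which keeps the propargyl group and lacks benzyl, gives 240 nM, while compound 2 gives 10000 nM; nothing shows how compound 2 behaves once its propargyl group is gone. Compound 3 retains the benzyl group tied to the weak number of compound 2, and loses the propargyl group present in both measured compounds. The expectation is therefore no improvement and a likely further weakening, with wide uncertainty. For compound 3 the estimated value is 30000 nM, within 5000 nM to 200000 nM, meaning an expected step of a 3.0-fold higher number from compound 2 to compound 3 (0.48 log units; beyond the scatter).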

Compound 3, inhibition constant: 33900 nM
The estimate for compound 3 lay 1.1-fold (0.05 log units) below the measured number, and the stated range covers the measured number.
By their numbers in this assay, from the lowest: compound 1; then compound 2; then compound 3.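

In this assay, hydrogen in place of propargyl on the amine nitrogen of the benzyl-bearing compound gives a 3.4-fold higher number from compound 2 to compound 3 (0.53 log units; beyond the scatter), so removing the propargyl group does not recover any of the inhibition lost on adding benzyl, and the propargyl group still counts for something with benzyl present. Phenyl in place of ethynyl on the saturated chain carbon bound to the amine nitrogen gives a 140-fold higher number from compound 1 to compound 3 (2.15 log units; beyond the scatter): both compounds are secondary amines, so that feature alone does not confer the low number of compound 1, and among these three compounds the ethynyl-bearing secondary amine stands apart. No experimental information is available to explain either step.

As far as these compounds go, it remains open whether the ethynyl end is needed as such, or whether an allyl or a propyl group on the same nitrogen would keep the number of compound 1. How a methyl group or a longer chain such as phenethyl would behave in place of benzyl on the amine nitrogen, and whether a primary amine on the shared core would retain any inhibition, also cannot be judged from these compounds.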